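The source may hold more compounds than are shown below. What is called first, only, known or untested is meant among the compounds shown, and "the series" means these compounds.

Of the compounds shown here, two have measured values so far. In a functional assay on HCT-116 cells (Homo sapiens) for antiproliferative activity, read by MTT assay, with a stated time of 72 h (on this read-out higher numbers stand for weaker inhibition and lower numbers for stronger inhibition), compound 1 `C/C=C1/[C@H](O[C@@H]2O[C@H](COC(C)=O)[C@@H](OC(C)=O)[C@H](OC(C)=O)[C@H]2OC(C)=O)OC=C(C(=O)OC)[C@H]1CC(=O)OCCCCCCCCCCCCCCC` gives 21000 nM. In this assay compound 2 `C/C=C1/[C@H](O[C@@H]2O[C@H](CO)[C@@H](O)[C@H](O)[C@H]2O)OC=C(C(=O)OC)[C@H]1CC(=O)OCCc1ccc(O)c(O)c1` gives 182000 nM, the higher of the two numbers and so the weaker inhibition, with a gap to compound 1 that lies beyond the scatter. These two compounds differ in more than one place, so their gap cannot be assigned to any single group.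

The next compound is compound 3 `C/C=C1/[C@H](O[C@@H]2O[C@H](CO)[C@@H](O)[C@H](O)[C@H]2O)OC=C(C(=O)OC)[C@H]1CC(=O)OCCc1ccccc1`, which departs from compound 2 in one place: phenyl in place of 3,4-dihydroxyphenyl on a saturated chain carbon, two bonds along the chain from an oxygen next to a carbonyl group.

Among the measured compounds shown here, no measured pair shows this change, so the only close anchor is compound 2 at 182000 nM. No step beyond the scatter is expected, with a slight lean toward stronger inhibition, and the estimated change is a 1.5-fold lower number from compound 2 to compound 3 (0.18 log units; within the scatter). In this assay the expected value for compound 3 is 120000 nM, with an estimated range of 45000 nM to 300000 nM.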

Compound 3, half-maximal inhibitory concentration: 25300 nM
Beside the measured number, compound 3's estimate is 4.7-fold (0.68 log units) above it; the measured number lies below the stated range.
By their numbers in this assay, from the lowest: compounds 1 and 3 (each within the scatter of the next); then compound 2.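

In this assay, among the compounds shown here, phenyl in place of 3,4-dihydroxyphenyl gives a 7.2-fold lower number from compound 2 to compound 3 (0.86 log units; beyond the scatter), the first single-place change that can be read. The position, on a saturated chain carbon, two bonds along the chain from an oxygen next to a carbonyl group, therefore responds to what the aromatic ring carries: the ring itself stays, while the two hydroxyl groups of 3,4-dihydroxyphenyl go, and with them its 2 hydrogen-bond donors and 2 hydrogen-bond acceptors, and inhibition becomes stronger. No measurement in hand bears on the reason for this step, which stands here as an observation only.

Open, as far as these compounds go, is whether both hydroxyl groups must go, since one step cannot tell if a 4-hydroxyphenyl or 3-hydroxyphenyl group would read like compound 2 or like compound 3, or how a 3,4-dimethoxyphenyl group would compare. Also open, from the compounds shown here alone, is how far the position tolerates other replacements, such as an aminophenyl group, a carboxylic acid or a longer chain ending in phenyl, and whether the step holds when the acetate esters of compound 1 are present.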